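A few compounds are considered here, and "the series" means these few. Any claim that something is new, unique, unknown or untested is made for them only; others in the source may bear on it.

Series notes, step from compound 1 to compound 4.

The read-out throughout is a functional assay on CCRF-CEM cells for agonist activity at C-X-C chemokine receptor type 4 (Homo sapiens), read by calcium flux, with a stated time of 25 min; a lower number here means that less compound is needed, a higher number that more compound is needed for the effect. Compound 1, `CN(C[C@H]1Cc2c(cccc2N2CCN(C3CC3)CC2)CN1)[C@H]1CCCc2cccnc21`, gives in this assay only a limit, > 30000 nM. Compound 2, `CN(C[C@H]1Cc2c(cccc2N2C[C@@H]3C[C@H]2CN3)CN1)[C@H]1CCCc2cccnc21`, likewise gives only a limit, > 30000 nM. Compound 3, `C[C@@H]1CN(c2cccc3c2C[C@H](CN(C)[C@H]2CCCc4cccnc42)NC3)C[C@H](C)N1C`, also gives only a limit, > 30000 nM. All three thus sit at the limit of > 30000 nM in this assay, at which 3 of the 3 values shown sit, so compound 1 stands at the limit of this assay without a number of its own. The three measured steps, a step that the two limits leave unreadable from compound 1 to compound 2, a step that the two limits leave unreadable from compound 1 to compound 3 and a step that the two limits leave unreadable from compound 2 to compound 3, cannot be read in size or direction because the limit of > 30000 nM in this assay, at which 3 of the 3 values shown sit, caps every value on both sides of each step. All three exchange the whole group on the aromatic carbon.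

Compound 4, `CN(C[C@H]1Cc2c(cccc2N2CCN(c3ccccn3)CC2)CN1)[C@H]1CCCc2cccnc21`, differs from compound 1 in one place: pyridin-2-yl in place of cyclopropyl on an amine nitrogen in a ring. Within the data shown here, none of the measured steps alters a substituent on the amine nitrogen in the ring, so no measured step bears directly on this change, and the capped values leave no direction to draw from. The expected step that the limit leaves unreadable from compound 1 to compound 4 therefore rests on compound 1 standing at the limit of > 30000 nM in this assay, at which 3 of the 3 values shown sit, and on no other information. Compound 4 is estimated to give 40000 nM in this assay, with a range of 10000 nM to 200000 nM, most probably reported again only as a limit.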

Compound 4, half-maximal effective concentration: > 30000 nM
Compound 4 ended at the assay's limit; the forecaster's own chance of this, stated with the estimate: 75%; the middle value is on the limit's open side.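

In this assay compound 4 gives > 30000 nM, a limit and not a number. No new step can be read between compound 1 and compound 4 because both stand at the limit: the limit of > 30000 nM in this assay, at which 4 of the 4 values shown sit.

The compounds shown leave open whether any group in these places gives a measurable value in this assay.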